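This account rests on a few compounds, and the source may have more. Where it says the series, first, only, none or still open, it means among the compounds named here.

Measured compounds:
compound 1 `Cc1ccc2oc(-c3ccc(N)cc3)cc(=O)c2c1`: 21300 nM
compound 2 `Cc1ccc2c(=O)cc(-c3ccc([N+](=O)[O-])cc3)oc2c1`: "not determined" (no result reported)
compound 3 `Cc1ccc2c(=O)cc(-c3ccc(Cl)cc3)oc2c1`: 6830 nM

In a functional assay on HepG2 cells (Homo sapiens) for cytotoxicity, read by MTT assay, with a stated time of 48 h (on this read-out lower numbers stand for stronger inhibition and higher numbers for weaker inhibition), compound 3 gives 6830 nM, the lowest of the two numbers recorded. Compound 1 gives 21300 nM, a higher number that lies beyond the scatter, while compound 2 has no result in this assay. Compound 4 `Cc1ccc2c(=O)cc(-c3ccc(N)cc3)oc2c1` is not yet measured. It differs from compound 3 by amino in place of chloro on an aromatic carbon. Within the data shown here, no step between measured compounds is available for this particular change. Compound 1 also carries an amino group on a closely related core and gives 21300 nM, so a move toward higher numbers is expected for compound 4, roughly a 2.6-fold higher number from compound 3 to compound 4 (0.42 log units; beyond the scatter). The estimate for compound 4 in this assay is 18000 nM, with a range from 7000 nM to 45000 nM.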

Compound 4, half-maximal inhibitory concentration: 40500 nM
Beside the measured number, compound 4's estimate is 2.3-fold (0.35 log units) below it; measured number inside the range.
By their numbers in this assay, from the lowest: compound 3; then compounds 1 and 4 (each within the scatter of the next).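

In this assay, putting amino in place of chloro on an aromatic carbon, para to a large group, gives a 5.9-fold higher number from compound 3 to compound 4 (0.77 log units; beyond the scatter) on an otherwise unchanged structure. Among these compounds, this is the first direct reading of this change at this position, and it favours chloro over amino, since the earlier compounds offered no such pair. Nothing measured here accounts for the step.

The compounds shown leave open how fluoro, methoxy or a carboxylic acid at this position would compare with chloro. They also leave open whether the same step would appear on the core of compound 1.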